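Swapping chloro for methoxy on the amide aryl ring

The compounds below may be only part of what the source reports. "The series", "measured", "known", "first", "only" and "open" are said of these compounds alone.

Measured compounds:
compound 1 `COc1cccc(C(=O)NCc2ccc(CNS(=O)(=O)c3ccc(C)cc3)cc2)c1` gives 10 nM
compound 2 `COc1ccccc1C(=O)NCc1ccc(CNS(=O)(=O)c2ccccc2)cc1` gives 1 nM
compound 3 `Cc1ccc(S(=O)(=O)NCc2ccc(CNC(=O)c3ccccc3Cl)cc2)cc1` gives 10 nM

In an assay on MDA-MB-231 cells for binding affinity to C-X-C chemokine receptor type 4 (Homo sapiens), read by immunofluorescence and microscopy, with stated times of 10 min and 30 min (a higher number here means that more compound is needed for the effect, a lower number that less compound is needed), compound 3 stands level with compound 1, the two being the highest numbers of the three, while compound 2 sits well below them. Compound 4 `COc1ccccc1C(=O)NCc1ccc(CNS(=O)(=O)c2ccc(C)cc2)cc1` is compound 3 with methoxy in place of chloro on an aromatic carbon. Among the compounds with values here, the one measured step that bears on the amide aryl ring is no change at the digits printed from compound 1 to compound 3 (within the scatter), so one substituent change there left the number unmoved. Within the data shown here, compound 2, which carries the same methoxy group but a different sulfonyl aryl ring, gives 1 nM, and no single step links it to compound 3. Compound 4 is therefore expected to move a 3.3-fold lower number from compound 3 to compound 4 (0.52 log units; beyond the scatter), landing between the two. The estimate for compound 4 is 3 nM, with a range from 1 nM to 10 nM.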

Compound 4, effective concentration (reported as EC, without a stated level of effect): 100 nM
Estimate against measurement, compound 4: 33-fold (1.52 log units) below; measured number above the stated range.
By their numbers in this assay, from the lowest: compound 2; then compounds 1 and 3 (each within the scatter of the next); then compound 4.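

In this assay, methoxy in place of chloro on the amide aryl ring is not a neutral swap, giving a 10-fold higher number from compound 3 to compound 4 (1.00 log units; beyond the scatter). The 2-methoxyphenyl in place of 3-methoxyphenyl also matters, giving a 10-fold higher number from compound 1 to compound 4 (1.00 log units; beyond the scatter), whereas the earlier step showed no change at the digits printed from compound 1 to compound 3 (within the scatter). Methyl in place of hydrogen on an aromatic carbon of the sulfonyl aryl ring gives a 100-fold higher number from compound 2 to compound 4 (2.00 log units; beyond the scatter), so that ring matters too.

Nothing shown here gives a reason for these steps. As far as these compounds go, whether fluoro or an amine in place of chloro would follow chloro or methoxy remains open.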